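This account rests on a few compounds, and the source may have more. Where it says the series, first, only, none or still open, it means among the compounds named here.

Measured compounds:
Compound 1 `COc1ccccc1-c1cn(C[C@H](O)[C@H]2OC(=O)C(OCc3ccccc3)=C2OCc2ccccc2)nn1` — > 100000 nM
Compound 2 `COc1ccccc1-c1cn(C/C=C2\OC(=O)C(OCc3ccccc3)=C2OCc2ccccc2)nn1` — > 100000 nM
Compound 3 `O=C1O/C(=C\Cn2cc(-c3cc(C(F)(F)F)cc(C(F)(F)F)c3)nn2)C(OCc2ccccc2)=C1OCc1ccccc1` — > 100000 nM

In a functional assay on CFPAC-1 cells (Homo sapiens) for antiproliferative activity, read by MTT assay, with a stated time of 72 h (on this read-out higher numbers stand for weaker inhibition and lower numbers for stronger inhibition), compound 1 gives > 100000 nM, which is a limit of the assay and not a number. Compound 2 likewise reaches only a limit in this assay, > 100000 nM. For compound 3 the result is again a limit, > 100000 nM. So compound 1 cannot be placed against the other two measured compounds; all three sit at the limit of > 100000 nM in this assay, at which 3 of the 3 values shown sit, and no ordering among them can be drawn.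

The piece follows the step from compound 1 to compound 4 `O=C1O[C@H]([C@@H](O)Cn2ccnn2)C(OCc2ccccc2)=C1OCc1ccccc1`, which has not yet been measured in this assay. The change is hydrogen in place of 2-methoxyphenyl on an aromatic carbon.

Within the data shown here, no step between measured compounds is available, and nothing here shows that removing the 2-methoxyphenyl group would lift the activity out of the region where all three measured compounds sit. The expectation is therefore a step from compound 1 to compound 4 of a number no higher from compound 1 to compound 4 (the limit leaves the size open), that is, none beyond the scatter. Compound 4 is estimated to give about 100000 nM, within a range from 30000 nM to 300000 nM, with a strong chance that this assay again reports only a limit.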

Compound 4, half-maximal inhibitory concentration: > 100000 nM
Compound 4 gave a limit, no number; the forecaster's own chance of this, stated with the estimate: 80%; the middle value lies on the limit itself.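

In this assay compound 4 gives > 100000 nM, which is a limit and not a number. Compound 1 also stands at a limit, so no step can be read between compound 1 and compound 4. The compounds shown leave open what structure, if any, would give a readable value in this assay: the limit of > 100000 nM in this assay, at which 4 of the 4 values shown sit.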